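Ring swap at the carbamate-bearing carbon: lipophilicity notes

The source may report more compounds than this note shows. Statements on the series, on what has been measured and on what is new or still open speak of the compounds shown alone.

Measured so far in a physicochemical assay for lipophilicity; on this read-out higher numbers stand for higher lipophilicity and lower numbers for lower lipophilicity:
compound 1 `CC1(C)CC(NC(=O)C(C)(C)/C=C/[C@H](NC(=O)OC(C)(C)C)c2ccccc2)CC(C)(C)N1` gives 4.2
compound 2 `CC1(C)CC(NC(=O)C(/C=C/[C@@H](NC(=O)OC(C)(C)C)c2ccc(F)cc2)(Cc2ccc(F)cc2)Cc2ccc(F)cc2)CC(C)(C)N1` gives 7.9
compound 3 `CC1(C)CC(NC(=O)C(/C=C/[C@H](NC(=O)OC(C)(C)C)c2ccc(F)cc2)(Cc2ccc(F)cc2)Cc2ccc(F)cc2)CC(C)(C)N1` gives 7.9

Compound 2 stands level with compound 3 at the digits printed, the two together the highest of the three numbers, while compound 1 sits well lower. Going by the values given here, the only step between compounds that differ in one place, no change at the digits printed from compound 2 to compound 3 (within the scatter), lies within the scatter, which fits because of the fact that compounds 2 and 3 differ only in the configuration as drawn. Compound 4 `CC1(C)CC(NC(=O)C(/C=C/[C@@H](NC(=O)OC(C)(C)C)c2ccoc2)(Cc2ccc(F)cc2)Cc2ccc(F)cc2)CC(C)(C)N1` differs from compound 2 by furan-3-yl in place of 4-fluorophenyl on a saturated chain carbon bound to an amide-type nitrogen and a double-bonded chain carbon. Among the compounds with values here, no measured step exchanges one aromatic ring for another, so the configurational step gives no guide to the size of this change. A downward step a number 1.10 log units lower from compound 2 to compound 4 (beyond the scatter) in this assay is nonetheless expected. Compound 4 is estimated at 6.8, between 6.2 and 7.4.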

Compound 4, partition coefficient: 6
The estimate for compound 4 lay 0.80 log units above the measured number; measured number below the stated range.
By their numbers in this assay, from the lowest: compound 1; then compound 4; then compounds 2 and 3 (each within the scatter of the next).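

The carbon bound to an amide-type nitrogen and a double-bonded chain carbon responds strongly to its ring in this assay: furan-3-yl in place of 4-fluorophenyl gives a number 1.90 log units lower from compound 2 to compound 4 (beyond the scatter). Configuration at this carbon gave only no change at the digits printed from compound 2 to compound 3 (within the scatter), so the ring exchange is the first change here to move the read-out. No available finding accounts for the size of this step.

This single pair changes ring size, hetero atom and fluorine together, leaving their shares unseparated. As far as these compounds go, whether thiophen-3-yl or pyridin-3-yl at this place would follow furan-3-yl remains open.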